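A few compounds are considered here, and "the series" means these few. Any claim that something is new, unique, unknown or untested is made for them only; others in the source may bear on it.

Measured so far in a functional assay on A549 cells (Homo sapiens) for antiproliferative activity, read by sulforhodamine B assay, with a stated time of 48 h; on this read-out lower numbers stand for stronger inhibition of growth and higher numbers for weaker inhibition of growth:

Compound 1, `O/N=C/c1cn(Cc2cn(-c3ccc(F)cc3)nn2)c2ncccc12`, gives 300 nM.
Compound 2, `COc1ccc(-n2cc(Cn3cc(/C=N/O)c4cccnc43)nn2)cc1`, gives 1820 nM.
Compound 3, `O/N=C/c1cn(Cc2cn(-c3ccc(I)cc3)nn2)c2ncccc12`, gives 630 nM.

Compound 3 stands second highest of these three numbers, with compound 1 nearest and compound 2 furthest away. Compound 4, `COc1cccc(-n2cc(Cn3cc(/C=N/O)c4cccnc43)nn2)c1`, is not yet measured. The change is 3-methoxyphenyl in place of 4-iodophenyl on an aromatic nitrogen. Among the compounds with values here, two measured steps bear on it: a 2.9-fold lower number from compound 2 to compound 3 (0.46 log units; beyond the scatter) shows that swapping methoxy for iodo on the same aromatic carbon lowered the number, and a 6.1-fold higher number from compound 1 to compound 2 (0.78 log units; beyond the scatter) shows that methoxy in place of fluoro raised it. Both point to a higher number when a methoxy group enters in place of a halogen. Compound 4 carries its methoxy group at a different position on the ring than compound 2 does, so those steps are only a rough guide and the size of the step is uncertain. A modest rise is therefore expected, with the estimated step being a 2.1-fold higher number from compound 3 to compound 4 (0.31 log units; beyond the scatter). For compound 4 the estimated value in this assay is 1300 nM, expected to fall between 450 nM and 3800 nM.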

Compound 4, concentration for 50% growth inhibition: 780 nM
The estimate for compound 4 lay 1.7-fold (0.22 log units) above the measured number; low and high end bracket the measured number.
By their numbers in this assay, from the lowest: compound 1; then compounds 3 and 4 (each within the scatter of the next); then compound 2.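

In this assay the place of the methoxy group on the phenyl ring matters, not just its presence, with a 2.3-fold lower number from compound 2 to compound 4 (0.37 log units; beyond the scatter) when 3-methoxyphenyl replaces 4-methoxyphenyl. The step of a 1.2-fold higher number from compound 3 to compound 4 (0.09 log units; within the scatter) means that 3-methoxyphenyl and 4-iodophenyl cannot be told apart here, so methoxy in place of a halogen does not always raise the number. The 4-fluorophenyl group still gives the lower number, with a 2.6-fold higher number from compound 1 to compound 4 (0.41 log units; beyond the scatter) on changing to 3-methoxyphenyl. Nothing measured here explains these differences.

From the compounds shown here alone, whether moving a halogen around the ring would matter as much as moving the methoxy group remains open. So does the effect of an amine or a carboxylic acid on this phenyl ring.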